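The source may report more compounds than this note shows. Statements on the series, on what has been measured and on what is new or still open speak of the compounds shown alone.

Three members of the series have been taken through an ADME assay on Huh-7 cells (Homo sapiens) for cytotoxicity, with a stated time of 72 h; a higher number here means that more compound is tolerated, a lower number that less compound is tolerated. Compound 1 `CCS(=O)(=O)Nc1ccc2c(c1)S(=O)(=O)N=C(c1c(O)c(-c3cccs3)nn(CCC(C)C)c1=O)N2` gives > 33000 nM, which is a limit of the assay and not a number. Compound 2 `CC(C)CCn1nc(C2CCCC2)c(O)c(C2=NS(=O)(=O)c3cc(NS(C)(=O)=O)ccc3N2)c1=O` gives > 1000 nM, again only a limit. Compound 3 `CCC(C)CCn1nc(-c2cccs2)c(O)c(C2=NS(=O)(=O)c3cc(NS(C)(=O)=O)ccc3N2)c1=O` gives > 1000 nM, also a limit. Compound 3 thus sits at the limit of > 1000 nM in this assay, at which 2 of the 3 values shown sit, and with every value shown being a limit no measured step can be read among the three. Compound 4 `CS(=O)(=O)Nc1ccc2c(c1)S(=O)(=O)N=C(c1c(O)c(-c3cccs3)nn(CC3(C(F)(F)F)CC3)c1=O)N2` differs from compound 3 by 1-(trifluoromethyl)cyclopropyl in place of 2-methylbutyl on a saturated chain carbon bound to an aromatic nitrogen. Nothing among the three values points to a direction for this change, so no step beyond the scatter is expected in this assay; the expected step is a step that the limit leaves unreadable from compound 3 to compound 4. Compound 4 is expected to give 20000 nM in this assay, within 3000 nM to 100000 nM, most likely reported once more as a limit.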

Compound 4, half-maximal cytotoxic concentration: > 1000 nM
Compound 4 gave a limit, no number; the forecaster's own chance of this, stated with the estimate: 80%; the middle value lies beyond the limit too.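

In this assay compound 3 and compound 4 both give limits, not numbers, so no step can be read between them. The compounds shown leave open where the half-maximal cytotoxic concentration of either compound actually lies.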